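Aryl variation at the hydrazone carbon: expectation for compound 4

A few compounds are considered here, and "the series" means these few. Any claim that something is new, unique, unknown or untested is made for them only; others in the source may bear on it.

Measured compounds in a functional assay on A549 cells (Homo sapiens) for cytotoxicity, read by MTT assay, with a stated time of 72 h; on this read-out higher numbers stand for weaker inhibition and lower numbers for stronger inhibition:
compound 1 `CN(C)CCn1cnnc1-c1cc(Oc2ccc(NC(=O)N/N=C/c3ccccc3)cc2F)ccn1`, 1860 nM
compound 2 `CN(C)CCn1cnnc1-c1cc(Oc2ccc(NC(=O)N/N=C/c3ccc(F)cc3)cc2F)ccn1`, 1790 nM
compound 3 `CN(C)CCn1cnnc1-c1cc(Oc2ccc(NC(=O)N/N=C/c3ccc(F)cc3F)cc2F)ccn1`, 1870 nM

Compound 3 gives the highest of the three numbers in this assay, yet its nearest neighbour is compound 1 and its furthest is compound 2, and both gaps are within the scatter, so no order among the three can be read from these values.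

Compound 4 `COc1cc(/C=N/NC(=O)Nc2ccc(Oc3ccnc(-c4nncn4CCN(C)C)c3)c(F)c2)ccc1O` differs from compound 3 in one place: 4-hydroxy-3-methoxyphenyl in place of 2,4-difluorophenyl on a carbon with a double bond to nitrogen.

The measured steps that bear on this position are a 1.0-fold lower number from compound 1 to compound 2 (0.02 log units; within the scatter), a 1.0-fold higher number from compound 2 to compound 3 (0.02 log units; within the scatter) and a 1.0-fold higher number from compound 1 to compound 3 (0.00 log units; within the scatter). Each of them exchanges hydrogen and fluoro on the same aryl group, and each is within the scatter. Among the measured compounds shown here, the change to compound 4 is of a different kind, bringing in a hydrogen-bond donor and two acceptors, and no measured step covers such a change. For the measured compounds named here, the only evidence from this series is that the aryl group on the carbon with a double bond to nitrogen has so far tolerated substitution without movement in this assay.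

Compound 4 is therefore expected to give a step of a 1.0-fold lower number from compound 3 to compound 4 (0.02 log units; within the scatter), that is no change beyond the scatter, with a range widened for the untested type of substituent. The estimate for compound 4 in this assay is 1800 nM, between 800 nM and 4500 nM.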

Compound 4, half-maximal inhibitory concentration: > 100000 nM
Compound 4 was reported as a limit; the forecaster's own chance of this, stated with the estimate: 5%; at least 55-fold (1.74 log units) between middle value and limit.
By their numbers in this assay, from the lowest: compounds 2, 1 and 3 (each within the scatter of the next). At a limit, above all of these: compound 4.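

Compound 4 stands at a limit of this assay and not at a number: the limit of > 100000 nM in this assay, at which 1 of the 4 values shown sits. Measured against all three earlier aryl groups, the change is large, with an at least 53-fold higher number from compound 3 to compound 4 (1.72 log units; beyond the scatter) and an at least 55-fold higher number from compound 2 to compound 4 (1.74 log units; beyond the scatter) and also an at least 53-fold higher number from compound 1 to compound 4 (1.73 log units; beyond the scatter), so the limit lies far from the tight cluster of the fluoro and hydrogen variants. Among the compounds shown here, the aryl group on the carbon with a double bond to nitrogen is therefore not freely exchangeable: phenyl, 4-fluorophenyl and 2,4-difluorophenyl stay within the scatter of each other, whereas 4-hydroxy-3-methoxyphenyl, the only one of these groups with a hydrogen-bond donor or acceptors, gives a far higher number on this read-out.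

The compounds shown do not separate the hydroxy group from the methoxy group, so it remains open whether one of them alone, as in 4-hydroxyphenyl or 3-methoxyphenyl, accounts for the step or whether the pair is required. Also open, from the compounds shown here alone, is how other groups at this position would behave, such as 4-aminophenyl, 4-carboxyphenyl or a longer alkoxy chain in place of the methoxy group.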